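The source may hold more compounds than are shown below. What is called first, only, known or untested is meant among the compounds shown, and "the series" means these compounds.

Measured so far in a functional assay on MOLT-4 cells (Homo sapiens) for cytotoxicity, read by sulforhodamine B assay, with a stated time of 48 h, tested at 100 uM; on this read-out higher numbers stand for a weaker effect at the one concentration tested and lower numbers for a stronger effect:
compound 1, `COc1cc(-c2cc(/C=C/C(=O)c3ccc(Cl)c(Cl)c3)[nH]n2)cc(OC)c1OC`: -15%
compound 2, `COc1ccc(C(=O)/C=C/c2cc(-c3cc(OC)c(OC)c(OC)c3)n[nH]2)cc1OC`: -23%
compound 3, `COc1cc(-c2cc(/C=C/C(=O)c3ccc(F)c(F)c3)[nH]n2)cc(OC)c1OC`: -14%

Compound 2 has the lowest of the three numbers in this assay, yet its distance to the other two is small: a number 8 percentage points lower from compound 1 to compound 2 (within the scatter) and a number 9 percentage points higher from compound 2 to compound 3 (within the scatter). The remaining pair behaves the same way, a number 1 percentage points higher from compound 1 to compound 3 (within the scatter). Among the measured compounds shown here, all three values therefore sit together, and no compound can be called stronger or weaker than another on these data.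

Compound 4, `COc1cc(C(=O)/C=C/c2cc(-c3cc(OC)c(OC)c(OC)c3)n[nH]2)cc(OC)c1OC`, is the unmeasured analogue. Its structural change: methoxy in place of hydrogen on an aromatic carbon. The three measured steps all alter the aryl group attached to the carbonyl carbon, swapping 3,4-dichlorophenyl, 3,4-dimethoxyphenyl and 3,4-difluorophenyl against one another, and every one of them stays within the scatter. The change to compound 4 also sits on that aryl group, so the expectation is a step of a number 3 percentage points higher from compound 2 to compound 4 (within the scatter), not beyond the scatter. Compound 4 is thus estimated at -20%, with a range from -35% to -5%.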

Compound 4, a percentage reported as activity, at one concentration (the size of the read-out at that concentration, not a potency): -15%
Compound 4: the middle estimate sits 5 percentage points below what was measured; low and high end bracket the measured number.
By their numbers in this assay, from the lowest: compounds 2, 1, 4 and 3 (each within the scatter of the next).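

In this assay methoxy in place of hydrogen, ortho to a methoxy group and meta to a large group, gives a number 8 percentage points higher from compound 2 to compound 4 (within the scatter) and so leaves no readable difference. The earlier steps shown here only exchanged one substituted aryl group on the carbonyl carbon for another, whereas this step adds a group at a site of that aryl group that carried hydrogen, and the addition is equally silent at the one concentration tested. No measured information bears on why the read-out stays in place.

Open, from the compounds shown here alone, is whether an amine or a carboxylic acid on this aromatic carbon would give a step beyond the scatter. Also open, going by these compounds, is whether a longer chain in place of this methoxy would separate itself from compound 2 in this assay at all.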